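The source may hold more compounds than are shown below. What is called first, only, known or untested is meant among the compounds shown, and "the series" means these compounds.

Measured in a functional assay on MDA-MB-231 cells (Homo sapiens) for antiproliferative activity, read by MTT assay, with a stated time of 72 h; a lower number here means a stronger inhibitor, a higher number a weaker inhibitor:
Compound 1 `O=C(O)c1ccc(OCCOc2ccc3cc2COC/C=C/COCc2cccc(c2)-c2ccnc(n2)N3)cc1`: 54200 nM
Compound 2 `O=C(NO)c1cccc(NCCOc2ccc3cc2COC/C=C/COCc2cccc(c2)-c2ccnc(n2)N3)c1`: > 50000 nM, a limit

Compound 2 stands only at the limit of > 50000 nM in this assay, at which 1 of the 2 values shown sits. Compound 3 `O=C(O)CCCCCCOc1ccc2cc1COC/C=C/COCc1cccc(c1)-c1ccnc(n1)N2` carries 4-carboxybutyl in place of (3-(hydroxycarbamoyl)phenyl)amino on a saturated chain carbon, two bonds along the chain from an oxygen on an aromatic ring. Among the measured compounds shown here, the single measured step is a step that the limit leaves unreadable from compound 1 to compound 2, so it offers no size to carry over. Compound 1, the other carboxy compound, gives 54200 nM, so weak activity is expected again. The estimated at least 1.2-fold lower number from compound 2 to compound 3 (0.09 log units; that floor lies within the scatter) is expected to stay small in this assay, with no clear direction. For compound 3 the expected value is 40000 nM, with an estimated range of 15000 nM to 100000 nM.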

Compound 3, half-maximal inhibitory concentration: 12000 nM
For compound 3 the middle estimate is 3.3-fold (0.52 log units) above the measured one; the measured number lies below the stated range.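

In this assay compound 2 is held only at a limit: the limit of > 50000 nM in this assay, at which 1 of the 3 values shown sits. Even so, 4-carboxybutyl gives a first readable gain over the hydroxycarbamoyl compound, an at least 4.1-fold lower number from compound 2 to compound 3 (0.61 log units; beyond the scatter). With a carboxy group on both sides, a 4.5-fold lower number from compound 1 to compound 3 (0.65 log units; beyond the scatter) shows that this position, on a saturated chain carbon, two bonds along the chain from an oxygen on an aromatic ring, responds to the group carrying the acid.

Compound 3 at 12000 nM still leaves open whether loss of the ring or the chain itself drives this step. As far as these compounds go, how a longer chain, or an amine at the chain end, would read also stays open.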